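This account rests on a few compounds, and the source may have more. Where it says the series, first, only, none or still open, it means among the compounds named here.

Measured compounds:
Compound 1 `COc1cc(C(=O)c2cn(-c3cccc(C)c3)cc2-c2ccsc2)cc(OC)c1OC`: 65 nM
Compound 2 `COc1cc(C(=O)c2cn(-c3cccc(C)c3)cc2-c2ccco2)cc(OC)c1OC`: 23 nM
Compound 3 `COc1cc(C(=O)c2cn(-c3ccc(F)cc3)cc2-c2ccsc2)cc(OC)c1OC`: 15 nM

All three numbers come from a functional assay on MCF7 cells (Homo sapiens) for inhibition, with a stated time of 96 h; a lower number here means a stronger inhibitor, a higher number a weaker inhibitor. Compound 1 and compound 2 share a core and differ by one change, (furan-2-yl in place of thiophen-3-yl on an aromatic carbon), which gave a 2.8-fold lower number from compound 1 to compound 2 (0.45 log units; beyond the scatter). Compound 1 and compound 3 differ on the aromatic nitrogen, (4-fluorophenyl in place of 3-methylphenyl on an aromatic nitrogen), and that change gave a 4.3-fold lower number from compound 1 to compound 3 (0.64 log units; beyond the scatter). Compound 3 has the lowest of the three measured numbers, though compound 2 lies within the scatter of it.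

Compound 4 `COc1cc(C(=O)c2cn(-c3ccc(F)cc3)cc2-c2ccco2)cc(OC)c1OC` is not yet measured. It relates to compound 3 as compound 2 relates to compound 1: furan-2-yl in place of thiophen-3-yl on an aromatic carbon. The surroundings are not identical: in compound 3 the ring atom two ring bonds away bears a 4-fluorophenyl group, whereas in compound 1 it bears a 3-methylphenyl group, so this is the same kind of change rather than the same change. For compound 4 the step expected in this assay is a 2.1-fold lower number from compound 3 to compound 4 (0.33 log units; beyond the scatter). Within the data shown here, that expectation rests on the single earlier instance, a 2.8-fold lower number from compound 1 to compound 2 (0.45 log units; beyond the scatter), taken somewhat smaller because compound 3 already gives 15 nM. Compound 4 is estimated at 7 nM, expected to fall between 3 nM and 16 nM.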

Compound 4, half-maximal inhibitory concentration: 17 nM
The estimate for compound 4 lay 2.4-fold (0.39 log units) below the measured number; the whole stated range lies below it.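

With 4-fluorophenyl on the ring nitrogen, furan-2-yl in place of thiophen-3-yl in this assay gives a 1.1-fold higher number from compound 3 to compound 4 (0.05 log units; within the scatter), so the step seen with 3-methylphenyl does not carry over to this core: the same change on two cores in this assay, a 2.8-fold lower number (0.45 log units; beyond the scatter) from compound 1 to compound 2 and a 1.1-fold higher number (0.05 log units; within the scatter) from compound 3 to compound 4, 3.2-fold (0.51 log units) apart, beyond the scatter of two such steps. Read the other way, 4-fluorophenyl in place of 3-methylphenyl gives a 1.4-fold lower number from compound 2 to compound 4 (0.13 log units; within the scatter) when furan-2-yl is present, a smaller step than with thiophen-3-yl: the same change on two cores in this assay, a 4.3-fold lower number (0.64 log units; beyond the scatter) from compound 1 to compound 3 and a 1.4-fold lower number (0.13 log units; within the scatter) from compound 2 to compound 4, 3.2-fold (0.51 log units) apart, beyond the scatter of two such steps. The two gaps come from one set of four compounds, so they show that these two changes do not add here, but not why, nor how either change behaves on any other core.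

Still open, from the compounds shown here alone, is whether the same lack of addition holds for other groups at the two places, such as thiophen-2-yl or a pyridine ring in place of furan-2-yl, or a chlorine or methoxy group in place of the fluorine on the phenyl ring. Also open, going by these compounds, is whether it extends beyond this assay.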